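The source may report more compounds than this note shows. Statements on the series, on what has been measured and on what is new or still open speak of the compounds shown alone.

Measured compounds and their values in a functional assay on HUVEC cells (Homo sapiens), read by scintillation counting and thymidine incorporation, with a stated time of 24 h; a higher number here means a weaker inhibitor, a lower number a stronger inhibitor:

compound 1, `CCC(C)n1ncn(-c2ccc(N3CCN(c4ccc(OC[C@@H]5CO[C@@](CC)(c6ccc(Cl)cc6Cl)O5)cc4)CC3)cc2)c1=O`: 353 nM
compound 2, `CCC(C)n1ncn(-c2ccc(N3CCN(c4ccc(OC[C@@H]5CO[C@@](CC6CCCC6)(c6ccc(Cl)cc6Cl)O5)cc4)CC3)cc2)c1=O`: 512 nM
compound 3, `CCC(C)n1ncn(-c2ccc(N3CCN(c4ccc(OC[C@@H]5CO[C@@](CN6CCN(C)CC6)(c6ccc(Cl)cc6Cl)O5)cc4)CC3)cc2)c1=O`: 396 nM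

Compound 3 holds the second highest of the three numbers. Its nearest neighbour is compound 1, with a 1.1-fold higher number from compound 1 to compound 3 (0.05 log units; within the scatter); its furthest is compound 2, with a 1.3-fold lower number from compound 2 to compound 3 (0.11 log units; within the scatter). All three compounds share one core and differ only in the group on a saturated chain carbon bound to a saturated ring carbon.

Compound 4, `CCC(C)n1ncn(-c2ccc(N3CCN(c4ccc(OC[C@@H]5CO[C@@](Cn6ccnc6C)(c6ccc(Cl)cc6Cl)O5)cc4)CC3)cc2)c1=O`, has not yet been measured in this assay. It differs from compound 3 in exactly that place: 2-methyl-1H-imidazol-1-yl in place of 4-methylpiperazin-1-yl on a saturated chain carbon bound to a saturated ring carbon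

For the measured compounds named here, every measured step so far changes the same position. From methyl to cyclopentyl, a 1.5-fold higher number from compound 1 to compound 2 (0.16 log units; within the scatter); from methyl to 4-methylpiperazin-1-yl, a 1.1-fold higher number from compound 1 to compound 3 (0.05 log units; within the scatter); and from cyclopentyl to 4-methylpiperazin-1-yl, a 1.3-fold lower number from compound 2 to compound 3 (0.11 log units; within the scatter). None of these moved the number beyond the scatter, so the group at this position has shown no influence on the read-out within these three compounds. The swap to 2-methyl-1H-imidazol-1-yl is therefore expected to give a 1.0-fold higher number from compound 3 to compound 4 (0.00 log units; within the scatter), that is, no step beyond the scatter. For compound 4 the estimate is 400 nM, with a likely range from 200 nM to 800 nM.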

Compound 4, half-maximal inhibitory concentration: 173 nM
Compound 4: middle estimate off by 2.3-fold (0.36 log units), on the high side; measured number outside the range, below it.
By their numbers in this assay, from the lowest: compound 4; then compounds 1, 3 and 2 (each within the scatter of the next).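

In this assay this position turns out not to be indifferent after all: methyl, cyclopentyl and 4-methylpiperazin-1-yl could not be told apart, whereas 2-methyl-1H-imidazol-1-yl gives a 2.3-fold lower number from compound 3 to compound 4 (0.36 log units; beyond the scatter) and a 3.0-fold lower number from compound 2 to compound 4 (0.47 log units; beyond the scatter) and a 2.0-fold lower number from compound 1 to compound 4 (0.31 log units; beyond the scatter) on the same saturated chain carbon. Each step is modest, but together they make compound 4 the strongest inhibitor of the four, the first separation seen at this position. The swap from compound 3 keeps the counts of nitrogen atoms, hydrogen-bond donors and acceptors and the net charge unchanged while replacing a six-membered non-aromatic ring with a five-membered aromatic one, yet nothing available explains why the number falls.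

With a single imidazole example, the methyl on the ring and the ring itself cannot be separated, so an imidazol-1-yl without the methyl would be the direct comparison. A phenyl or a pyrazol-1-yl at this place would further show whether other aromatic rings give a similar step or whether it is particular to the 2-methyl-1H-imidazol-1-yl group.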